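Same Atoms, Joined Differently: Compound 3 to Compound 4

The compounds below may be only part of what the source reports. "The series", "measured", "known", "first", "only" and "open" are said of these compounds alone.

Of the compounds shown here, three sharing one core have been measured in a physicochemical assay for lipophilicity; a lower number here means a more polar compound, a higher number a more lipophilic compound. Compound 1 (`Cc1ccc(NC(=O)C[C@H](CCC(=O)O)c2noc(-c3cc(CC(C)C)on3)c2C2CC2)c(Cl)c1`) gives 3.9. Compound 2 (`Cc1ccc(NC(=O)C[C@H](CCC(=O)O)c2noc(-c3ncc(CC(C)C)o3)c2C2CC2)c(Cl)c1`) gives 3.7. Compound 3 (`Cc1ccc(NC(=O)C[C@H](CCC(=O)O)c2noc(-c3ncc(CC(C)C)s3)c2C2CC2)c(Cl)c1`) gives 4, which stands within the scatter of both others: the steps are a number 0.10 log units higher from compound 1 to compound 3 (within the scatter) and a number 0.30 log units higher from compound 2 to compound 3 (within the scatter).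

Compound 4 (`Cc1ccc(NC(=O)C[C@H](CCC(=O)O)c2noc(-c3cnc(CC(C)C)s3)c2C2CC2)c(Cl)c1`) has not yet been measured. It carries the same atoms as compound 3, joined differently: 2-isobutyl-1,3-thiazol-5-yl in place of 5-isobutyl-1,3-thiazol-2-yl on an aromatic carbon. The 2-isobutyl-1,3-thiazol-5-yl group takes the place of 5-isobutyl-1,3-thiazol-2-yl on an aromatic carbon, next to the ring oxygen and next to the ring atom that bears a cyclopropyl group.

Going by the values given here, no measured pair makes this exact exchange. The nearest evidence comes from the three steps that replace one isobutyl-bearing ring at this same place. Besides the two above, there is a number 0.20 log units lower from compound 1 to compound 2 (within the scatter), and none of the three leaves the scatter. On that basis, no shift beyond the scatter is expected in this assay, and the expected step is a number 0.10 log units lower from compound 3 to compound 4 (within the scatter). The estimate for compound 4 is 3.9, with an expected range from 3.5 to 4.3.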

Compound 4, distribution coefficient: 3.8
Compound 4: middle estimate off by 0.10 log units, on the high side; measured number inside the range.
By their numbers in this assay, from the lowest: compounds 2, 4, 1 and 3 (each within the scatter of the next).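

Going by these compounds alone, compound 4 adds a kind of exchange that the earlier compounds did not contain: the atoms stay the same, but the thiazole is joined differently, as 2-isobutyl-1,3-thiazol-5-yl in place of 5-isobutyl-1,3-thiazol-2-yl, and in this assay this gives a number 0.20 log units lower from compound 3 to compound 4 (within the scatter) at this position. Its steps from the other two rings, a number 0.10 log units higher from compound 2 to compound 4 (within the scatter) and a number 0.10 log units lower from compound 1 to compound 4 (within the scatter), also stay within the scatter, so all six steps among the four compounds do, whether the ring's hetero atoms or its points of attachment are exchanged. No measurement shown here explains why these numbers stay so close together.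

The compounds leave open whether this holds once the isobutyl group gives way to a chain carrying an amine or a carboxylic acid, or once the isobutyl-bearing ring gives way to a phenyl ring. They also leave open whether the same exchanges stay as close when the neighbouring cyclopropyl group gives way to a methyl group.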